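The compounds below may be only part of what the source reports. "The series", "measured", "known", "first", "only" and "open" are said of these compounds alone.

Compound 1 `COc1cc(C(=O)c2cn(-c3ccc(Cl)cc3)cc2-c2ccccc2)cc(OC)c1OC`: 140 nM
Compound 2 `COc1cc(C(=O)c2cn(-c3ccccc3)cc2-c2ccccc2C)cc(OC)c1OC`: 190 nM

In a functional assay on MCF7 cells (Homo sapiens) for cytotoxicity, read by MTT assay, with a stated time of 96 h (a lower number here means a stronger inhibitor, a higher number a weaker inhibitor), compound 2 gives 190 nM, which lies within the usual scatter of compound 1 at 140 nM, so the two cannot be told apart. Compound 3 `COc1cc(C(=O)c2cn(-c3ccccc3)cc2-c2cccc([N+](=O)[O-])c2)cc(OC)c1OC` carries 3-nitrophenyl in place of 2-methylphenyl on an aromatic carbon. Among the measured compounds shown here, no two measured compounds differ in only one place, so the data do not show what such a swap does. In this assay the expected change is a 1.6-fold higher number from compound 2 to compound 3 (0.20 log units; within the scatter), a slight weakening that may not exceed the scatter. Compound 3 is estimated at 300 nM, with a range of 70 nM to 1300 nM.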

Compound 3, half-maximal inhibitory concentration: 50 nM
Estimate against measurement, compound 3: 6.0-fold (0.78 log units) above, and the stated range ends above it.
By their numbers in this assay, from the lowest: compound 3; then compounds 1 and 2 (each within the scatter of the next).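

In this assay, putting 3-nitrophenyl in place of 2-methylphenyl on this aromatic carbon gives a 3.8-fold lower number from compound 2 to compound 3 (0.58 log units; beyond the scatter), a real gain in potency. This shows that the position, two ring bonds from the ring nitrogen, is sensitive to the group it carries. No measurement shown explains this gain.

The swap changes both the substituent on the phenyl ring and its place on that ring, so the compounds shown cannot separate these two changes. Going by these compounds, how 3-methylphenyl or 3-aminophenyl would behave at this position remains open.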